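The compounds below may be only part of what the source reports. "The series", "measured", "known", "first", "only" and "open" are said of these compounds alone.

Compound 3 `Cc1ccc(-c2noc3c2CCNCC3)cc1` gives 1140 nM in an assay on cells for displacement of a labelled ligand from 5-hydroxytryptamine receptor 5A (Homo sapiens), read by scintillation counting, with a stated time of 1.5 h (on this read-out higher numbers stand for weaker inhibition and lower numbers for stronger inhibition), the lowest of the two numbers shown; compound 1 `Fc1ccc(-c2noc3c2CCNCC3)cc1` gives 1230 nM in this assay, and the gap between them lies within the scatter. Compound 2 `Cc1ccc(-c2n[nH]c3c2CCNCC3)cc1` gives only a limit in this assay, > 10000 nM, as recorded in the limit of > 10000 nM in this assay, at which 1 of the 3 values shown sits. Compound 4 `Clc1ccc(-c2noc3c2CCNCC3)cc1` differs from compound 3 by chloro in place of methyl on an aromatic carbon. Going by the values given here, the one comparable measured step, a 1.1-fold lower number from compound 1 to compound 3 (0.03 log units; within the scatter), stayed within the scatter, so for compound 4 no step beyond the scatter is expected in this assay, in either direction. The expected step is thus a 1.0-fold lower number from compound 3 to compound 4 (0.02 log units; within the scatter). Compound 4 is estimated at 1100 nM, with a range from 500 nM to 2500 nM.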

Compound 4, inhibition constant: > 10000 nM
Compound 4 gave a limit, no number; the forecaster's own chance of this, stated with the estimate: 3%; middle value at least 9.0-fold (0.95 log units) away from the limit.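

At this position, para to a large group, the substituent is not interchangeable: in this assay, fluoro and methyl stay within the scatter of each other, yet chloro gives an at least 8.7-fold higher number from compound 3 to compound 4 (0.94 log units; beyond the scatter) and an at least 8.1-fold higher number from compound 1 to compound 4 (0.91 log units; beyond the scatter). Exchanging one heavy atom on this aromatic carbon is thus enough to move the read-out beyond the scatter. The value of compound 4 is a limit, so both steps have a floor but no full size: the limit of > 10000 nM in this assay, at which 2 of the 4 values shown sit.

Going by these compounds, whether the change is peculiar to chloro or extends to bromo or trifluoromethyl stays open. So does whether methoxy or an amine at this place would match compound 1 and compound 3.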